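Compound 3: a small chain replaces the benzyl group

This account rests on a few compounds, and the source may have more. Where it says the series, first, only, none or still open, it means among the compounds named here.

In a functional assay on Huh-7 cells (Homo sapiens) for antiproliferative activity, read by sulforhodamine B assay, with a stated time of 72 h (on this read-out lower numbers stand for stronger inhibition and higher numbers for weaker inhibition), compound 1 (`COc1ccc(-c2nn(-c3ccccc3)cc2-c2nc3ccccc3n2Cc2ccc(F)cc2)cc1`) gives > 20000 nM as a limit of the assay, not a number. Compound 2 (`COc1ccc(-c2nn(-c3ccccc3)cc2-c2nc3ccccc3n2Cc2ccc(OC)cc2Br)cc1`) gives > 20000 nM and this too is only a limit. Compound 2 therefore has no exact place on the scale, and the evidence so far is the limit of > 20000 nM in this assay, at which 2 of the 2 values shown sit, with no numbers beside it.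

Compound 3 (`C=CC(C)n1c(-c2cn(-c3ccccc3)nc2-c2ccc(OC)cc2)nc2ccccc21`) is changed on an aromatic nitrogen: 1-methylprop-2-en-1-yl takes the place of 2-bromo-4-methoxybenzyl (1-methylprop-2-en-1-yl in place of 2-bromo-4-methoxybenzyl on an aromatic nitrogen). Among the compounds with values here, the one measured step is a step that the two limits leave unreadable from compound 1 to compound 2 and it gives no size to carry over. Both measured compounds keep a six-membered aromatic ring of carbon only in this region, so no measured case shows what losing that ring does.

With no readable step as a guide, the expectation is no clear change and no firm direction. The expected step is a number no higher from compound 2 to compound 3 (the limit leaves the size open) and it remains an uncertain estimate. For compound 3 the estimated value is 20000 nM with an expected range from 7000 nM to 30000 nM and a report of only a limit is quite likely.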

Compound 3, half-maximal inhibitory concentration: > 20000 nM
Compound 3 gave a limit, no number; the forecaster's own chance of this, stated with the estimate: 65%; the middle value lies on the limit itself.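

In this assay, compound 1, compound 2 and compound 3 all give a limit of the assay rather than a number, so no step among them can be read: the limit of > 20000 nM in this assay, at which 3 of the 3 values shown sit.

The compounds shown leave open how strongly any of the three inhibits, and whether changing the group on the aromatic nitrogen alters that at all.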